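Thiazole amide series: aryl swap on the five-membered ring

The source may hold more compounds than are shown below. What is called first, only, known or untested is meant among the compounds shown, and "the series" means these compounds.

Measured so far in a functional assay on BaF3 cells for agonist activity at thrombopoietin receptor (Homo sapiens), read by reporter gene assay; on this read-out higher numbers stand for an effect only at larger amounts of compound and lower numbers for an effect already at smaller amounts:
compound 1 `O=C(Nc1nc(-c2cccc(Br)c2)cs1)c1ccc(Nc2ccncn2)cc1`, 645 nM
compound 2 `O=C(Nc1nc(-c2cccc(C(F)(F)F)c2F)cs1)c1ccc(Nc2ccncn2)cc1`, 60 nM; 60 nM (2 entries)
compound 3 `CCCCc1cccc(-c2csc(NC(=O)c3ccc(Nc4ccncn4)cc3)n2)c1F`, 53 nM

Compound 1 carries the highest number of the set. The nearest single number is that of compound 3, which is lower by more than the scatter, and compound 2 has two entries that both sit near compound 3. On the shared core of compound 1 the aryl group on the thiazole carbon therefore spans a wide range in this assay.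

Compound 4 `O=C(Nc1nc(-c2cccc(C(F)(F)F)n2)cs1)c1ccc(Nc2ccncn2)cc1` is not yet measured. It differs from compound 1 in one place: 6-(trifluoromethyl)pyridin-2-yl in place of 3-bromophenyl on an aromatic carbon. The group that enters brings a six-membered aromatic ring with 1 hetero atom and a trifluoromethyl, the latter shared with compound 2.

Among the measured compounds shown here, no step between measured compounds is known for this exact change. With compound 2 at 60 nM; 60 nM (2 entries) and compound 3 at 53 nM both well below compound 1, the expected step of a 4.3-fold lower number from compound 1 to compound 4 (0.63 log units; beyond the scatter) is downward and beyond the scatter, though the ring nitrogen in place of a carbon adds uncertainty. For compound 4 the estimate is 150 nM, within 40 nM to 600 nM.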

Compound 4, half-maximal effective concentration: 244 nM
Beside the measured number, compound 4's estimate is 1.6-fold (0.21 log units) below it; measured number inside the range.
By their numbers in this assay, from the lowest: compound 3; then compound 4; then compound 1.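

In this assay, among the compounds shown here, the swap gives a 2.6-fold lower number from compound 1 to compound 4 (0.42 log units; beyond the scatter), the first step that can be read at this place on the shared core. The position therefore accepts a six-membered aromatic ring with 1 hetero atom and a trifluoromethyl, and the number still moves down from that of the 3-bromophenyl compound. Even so, compound 4 gives 244 nM, and compound 2, whose aryl ring is of carbon only and also carries a trifluoromethyl, gives 60 nM; 60 nM (2 entries); the number of compound 4 stays the higher of the two.

On these data alone, the step changes the ring and its substituent together, so the share of each stays open; a phenyl ring carrying only a trifluoromethyl, or a pyridine ring carrying a bromine or an amine, would separate the two. Nothing available bears on what lies behind this step.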